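Changing the benzyl aryl group: expected effect on inhibition

The source may hold more compounds than are shown below. What is called first, only, known or untested is meant among the compounds shown, and "the series" means these compounds.

Compound 1, `COc1ccc([C@@H]2CC(=O)c3c(O)cc(OCc4cn(Cc5ccc(C(F)(F)F)cc5)nn4)cc3O2)cc1O`, gives 17700 nM in a functional assay on RAW264.7 cells (Mus musculus) for inhibition, read by Griess assay, with stated times of 2 h and 24 h; on this read-out lower numbers stand for stronger inhibition and higher numbers for weaker inhibition.
Compound 2, `CCCn1cc(COc2cc(O)c3c(c2)O[C@H](c2ccc(OC)c(O)c2)CC3=O)nn1`, gives 9670 nM in this assay.
Compound 3, `COc1ccc([C@@H]2CC(=O)c3c(O)cc(OCc4cn(Cc5cccc(C#N)c5)nn4)cc3O2)cc1O`, gives 18000 nM in this assay.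

Compound 3 carries the highest of the three numbers, yet its steps to both others are small: a 1.0-fold higher number from compound 1 to compound 3 (0.01 log units; within the scatter) and a 1.9-fold higher number from compound 2 to compound 3 (0.27 log units; within the scatter) lie within the scatter, as does a 1.8-fold lower number from compound 1 to compound 2 (0.26 log units; within the scatter). On these numbers none of the three compounds can be set apart from the others.

Compound 4, `COc1ccc([C@@H]2CC(=O)c3c(O)cc(OCc4cn(Cc5ccc(C)cc5)nn4)cc3O2)cc1O`, differs from compound 3 by 4-methylphenyl in place of 3-cyanophenyl on a saturated chain carbon bound to an aromatic nitrogen. Among the measured compounds shown here, two measured steps bear on this change. The step of a 1.0-fold higher number from compound 1 to compound 3 (0.01 log units; within the scatter) exchanges one substituted phenyl for another at the same place, and the step of a 1.9-fold higher number from compound 2 to compound 3 (0.27 log units; within the scatter) exchanges ethyl for an aryl group there; neither moves the number beyond the scatter. The change to compound 4 is once more an exchange of one substituted phenyl for another at that place, so no step beyond the scatter is expected in this assay. The expected step is a 1.1-fold lower number from compound 3 to compound 4 (0.05 log units; within the scatter). Compound 4 is therefore estimated at 16000 nM, with a range from 7000 nM to 36000 nM.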

Compound 4, half-maximal inhibitory concentration: 16800 nM
Beside the measured number, compound 4's estimate is 1.1-fold (0.02 log units) below it; low and high end bracket the measured number.
By their numbers in this assay, from the lowest: compounds 2, 4, 1 and 3 (each within the scatter of the next).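

In this assay, 4-methylbenzyl in place of 3-cyanobenzyl gives a 1.1-fold lower number from compound 3 to compound 4 (0.03 log units; within the scatter), although the group that leaves has a nitrile and 1 hydrogen-bond acceptor while the group that enters has 0 hydrogen-bond acceptors. With methyl in place of trifluoromethyl on an aromatic carbon, the series shows a 1.1-fold lower number from compound 1 to compound 4 (0.02 log units; within the scatter), and with 4-methylphenyl in place of ethyl on a saturated chain carbon bound to an aromatic nitrogen it shows a 1.7-fold higher number from compound 2 to compound 4 (0.24 log units; within the scatter), so a third aryl group at this place still cannot be separated from the two aryl groups or the alkyl group seen before. Nothing independent of these numbers bears on this result.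

The compounds shown leave open whether a basic amine or a carboxylic acid on the benzyl ring, or a much longer alkyl chain at the same place, would move the number beyond the scatter. They also leave open whether changes to the shared core, rather than to this side of the molecule, would do so in this assay.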